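The source may hold more compounds than are shown below. What is called first, only, known or untested is meant among the compounds shown, and "the series" means these compounds.

Compounds measured in a functional assay for agonist activity at Alpha-1A adrenergic receptor (Homo sapiens); a lower number here means that less compound is needed, a higher number that more compound is needed for the effect:
compound 1 `CSc1c(F)cccc1NCC1=NCCN1` — 7.76 nM
compound 2 `CS(=O)(=O)c1c(F)cccc1NCC1=NCCN1` — 24 nM
compound 3 `CSc1ccc(C(F)(F)F)cc1NCC1=NCCN1` — 10.5 nM

Compound 4 `CS(=O)(=O)c1ccc(C(F)(F)F)cc1NCC1=NCCN1` has not yet been measured in this assay. It differs from compound 3 by methylsulfonyl in place of methylsulfanyl on an aromatic carbon. The same kind of change has already been made once, from compound 1 to compound 2, as methylsulfonyl in place of methylsulfanyl on an aromatic carbon, and there it produced a 3.1-fold higher number from compound 1 to compound 2 (0.49 log units; beyond the scatter). The two cases are not the same: in the earlier one the change sits ortho to a fluoro group, whereas in the new one it sits para to a trifluoromethyl group. How the core of compound 1 differs from the core of compound 3 is not broken down here. Compound 3 and compound 1 lie within the scatter of each other.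

Given only this single precedent, the expected step for compound 4 is a 2.9-fold higher number from compound 3 to compound 4 (0.46 log units; beyond the scatter), resting on the step from compound 1 to compound 2 being a 3.1-fold higher number from compound 1 to compound 2 (0.49 log units; beyond the scatter). Compound 4 is therefore estimated at 30 nM, with a range from 14 nM to 70 nM.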

Compound 4, half-maximal effective concentration: 1100 nM
Beside the measured number, compound 4's estimate is 37-fold (1.56 log units) below it; the whole stated range lies below it.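

In this assay, methylsulfonyl in place of methylsulfanyl gave a 100-fold higher number from compound 3 to compound 4 (2.02 log units; beyond the scatter). The change raised the number on both cores, but its size did not carry over from one core to the other: the same change on two cores in this assay, a 3.1-fold higher number (0.49 log units; beyond the scatter) from compound 1 to compound 2 and a 100-fold higher number (2.02 log units; beyond the scatter) from compound 3 to compound 4, 34-fold (1.53 log units) apart, beyond the scatter of two such steps. Among the compounds shown here, with only two pairs, this does not show which difference between the cores matters, whether it is the fluoro group, the trifluoromethyl group or where each one sits, nor does it give a rule for any further core.

The compounds shown leave open whether a core carrying a chloro, methoxy or nitrile group in place of trifluoromethyl would follow the smaller step or the larger one. They also leave open where a methylsulfinyl group would fall on either core.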